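Urea series: replacing 2,6-dichlorophenyl with cyclopentyl

The compounds below may be only part of what the source reports. "The series", "measured", "known", "first", "only" and "open" are said of these compounds alone.

Measured in a functional assay on HUVEC cells (Homo sapiens) for inhibition; on this read-out lower numbers stand for stronger inhibition and higher numbers for weaker inhibition:
- compound 1 `CN(c1ccc(NC(=O)Oc2ccccc2)cc1)c1ccnc(Nc2cccc(CS(C)(=O)=O)c2)n1`: 224 nM
- compound 2 `CN(c1ccc(N/C(S)=N/c2ccccc2)cc1)c1ccnc(Nc2cccc(CS(C)(=O)=O)c2)n1`: 6 nM
- compound 3 `CN(c1ccc(NC(=O)Nc2c(Cl)cccc2Cl)cc1)c1ccnc(Nc2cccc(CS(C)(=O)=O)c2)n1`: 29 nM

Compound 3, at 29 nM, holds the middle of the three numbers, higher than compound 2 and lower than compound 1. The next structure is compound 4 `CN(c1ccc(NC(=O)NC2CCCC2)cc1)c1ccnc(Nc2cccc(CS(C)(=O)=O)c2)n1`, with this change: cyclopentyl in place of 2,6-dichlorophenyl on an amide-type nitrogen. In short, cyclopentyl stands in place of 2,6-dichlorophenyl on an amide-type nitrogen.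

Three measured steps alter the same group: a 37-fold lower number from compound 1 to compound 2 (1.57 log units; beyond the scatter), a 7.7-fold lower number from compound 1 to compound 3 (0.89 log units; beyond the scatter) and a 4.8-fold higher number from compound 2 to compound 3 (0.68 log units; beyond the scatter). These steps are modest to large, so this group clearly matters in this assay. Among the compounds with values here, all three compounds keep a six-membered aromatic ring of carbon only in it, however, so no measured step shows what losing that ring does, and the direction is uncertain.

A modest rise is expected, and the estimated step is a 2.8-fold higher number from compound 3 to compound 4 (0.44 log units; beyond the scatter). For compound 4 the estimated value is 80 nM, with an expected range of 20 nM to 300 nM.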

Compound 4, half-maximal inhibitory concentration: 1 nM
Estimate against measurement, compound 4: 80-fold (1.90 log units) above; the measured number lies below the stated range.
By their numbers in this assay, from the lowest: compound 4; then compound 2; then compound 3; then compound 1.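

In this assay, an aromatic ring on this amide-type nitrogen proves unnecessary: cyclopentyl in place of 2,6-dichlorophenyl gives a 29-fold lower number from compound 3 to compound 4 (1.46 log units; beyond the scatter), the first step shown that removes the six-membered aromatic ring of carbon only, and its direction is downward. The cyclopentyl urea also surpasses the two phenyl-bearing linkers, with a 6.0-fold lower number from compound 2 to compound 4 (0.78 log units; beyond the scatter) and a 220-fold lower number from compound 1 to compound 4 (2.35 log units; beyond the scatter), making it the strongest inhibitor of the four shown. Nothing available explains this gain.

The step from compound 3 to compound 4 removes the ring and the two chlorines together, and a plain phenyl on the same urea would be needed to separate them. Also open, going by these compounds, is whether cyclopropyl, cyclohexyl or an open chain such as n-butyl on this nitrogen would hold the value, and whether a hydroxyl or an amine on the cyclopentyl ring would keep it.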